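A few compounds are considered here, and "the series" means these few. Any claim that something is new, unique, unknown or untested is made for them only; others in the source may bear on it.

Working notes on a set of compounds sharing one core, all read in an assay on IMR-32 cells for displacement of a labelled ligand from corticotropin-releasing factor receptor 1 (Homo sapiens), read by scintillation counting, with a stated time of 2 h; a higher number here means a weaker inhibitor, a lower number a stronger inhibitor. Compound 1 `CCc1nc(-c2ccc(Cl)cc2Cl)c(CC)nc1NC(COC)COC` gives 224 nM. Compound 2 `CCc1nc(-c2ccc(OC)cc2O)c(CC)nc1NC(CC)CC` gives 1180 nM. Compound 3 `CCC(CC)Nc1nc(C)c(-c2ccc(Cl)cc2Cl)nc1C` gives 27 nM. Compound 1 thus sits second highest of the three numbers: the gap to compound 2 lies beyond the scatter, and the wider gap to compound 3 lies beyond the scatter as well.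

Compound 4 `CCCN(CC1CC1)c1nc(CC)c(-c2ccc(Cl)cc2Cl)nc1CC` has not yet been measured in this assay. It differs from compound 1 in one place: (cyclopropylmethyl)(propyl)amino in place of (2-methoxy-1-(methoxymethyl)ethyl)amino on an aromatic carbon. Among the measured compounds shown here, no measured pair shows this change, so its size rests on judgement. The step of a 7.5-fold lower number from compound 1 to compound 4 (0.87 log units; beyond the scatter) is expected to lower the number beyond the scatter. For compound 4 the estimate in this assay is 30 nM, with a range from 8 nM to 120 nM.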

Compound 4, inhibition constant: 19.2 nM
Estimate against measurement, compound 4: 1.6-fold (0.19 log units) above; low and high end bracket the measured number.
By their numbers in this assay, from the lowest: compounds 4 and 3 (each within the scatter of the next); then compound 1; then compound 2.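

In this assay, among the compounds shown here, replacing (2-methoxy-1-(methoxymethyl)ethyl)amino with (cyclopropylmethyl)(propyl)amino gives a 12-fold lower number from compound 1 to compound 4 (1.07 log units; beyond the scatter), the first direct evidence that the group on this aromatic carbon alone can shift the number beyond the scatter. Compound 4 has no hydrogen-bond donor in this group, so a low number here does not require one. No measurement here accounts for the step.

The donor, both oxygens and the three-membered ring all change together, leaving their separate contributions unresolved. As far as these compounds go, how a dipropylamino or morpholine group would read at this position remains open.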